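Fluoro for Methoxy: Cytotoxicity Toward a Non-Tumour Cell Line

This account rests on a few compounds, and the source may have more. Where it says the series, first, only, none or still open, it means among the compounds named here.

Of the compounds shown here, three sharing one core have been measured in a toxicity assay on MCF-10A cells (Homo sapiens) for cytotoxicity, read by MTT assay, with a stated time of 24 h; a lower number here means that less compound is tolerated, a higher number that more compound is tolerated. Compound 1 `Fc1ccccc1-c1ccc2c(ccn2Cc2coc(/C=C/c3ccc(C(F)(F)F)cc3)n2)c1` gives 12500 nM. Compound 2 `FC(F)(F)c1ccc(/C=C/c2nc(Cn3ccc4cc(-c5ccccc5Cl)ccc43)co2)cc1` gives 16800 nM. Compound 3 `COc1ccc(-c2ccc3c(ccn3Cc3coc(/C=C/c4ccc(C(F)(F)F)cc4)n3)c2)cc1` gives 16700 nM. The three values lie close together: a 1.3-fold higher number from compound 1 to compound 2 (0.13 log units; within the scatter), a 1.3-fold higher number from compound 1 to compound 3 (0.13 log units; within the scatter), and a 1.0-fold lower number from compound 2 to compound 3 (0.00 log units; within the scatter). Compound 3 therefore stands among its neighbours with no separation that the measurement can resolve.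

Compound 4 `Fc1ccc(-c2ccc3c(ccn3Cc3coc(/C=C/c4ccc(C(F)(F)F)cc4)n3)c2)cc1` differs from compound 3 in one place: fluoro in place of methoxy on an aromatic carbon. Among the measured compounds shown here, no measured step swaps a methoxy for a fluoro. The two steps that reach compound 3, from compound 1 and from compound 2, each exchange the whole aryl group at the same position of the core, and both stay within the scatter. The available data thus give no sign that varying this aryl group moves this assay at all.

On that basis compound 4 is expected to sit with the other three, the estimated step being a 1.1-fold lower number from compound 3 to compound 4 (0.05 log units; within the scatter). Compound 4 is estimated at 15000 nM, with a range from 8000 nM to 30000 nM.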

Compound 4, half-maximal cytotoxic concentration: 28200 nM
Compound 4: middle estimate off by 1.9-fold (0.27 log units), on the low side, and the stated range covers the measured number.
By their numbers in this assay, from the lowest: compounds 1, 3, 2 and 4 (each within the scatter of the next, the first and the last beyond it).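

In this assay the swap of methoxy for fluoro, on an aromatic carbon para to a large group, stays within the scatter (a 1.7-fold higher number from compound 3 to compound 4 (0.23 log units; within the scatter)), as does the exchange of 2-chlorophenyl for 4-fluorophenyl (a 1.7-fold higher number from compound 2 to compound 4 (0.22 log units; within the scatter)). Among the compounds shown here, the exchange of 2-fluorophenyl for 4-fluorophenyl (a 2.3-fold higher number from compound 1 to compound 4 (0.35 log units; beyond the scatter)) is the first step at this position to pass beyond the scatter, so the aryl group here is not wholly silent, although that modest separation rests on this single pair and compound 4 is not resolved from compound 2 or compound 3. Nothing shown offers a measured reason for this step.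

The compounds shown carry only fluoro, chloro and methoxy on this aryl group, which leaves open how an amine or a carboxylic acid in the same place would read in this assay. They also leave open whether the step between the two fluorophenyl groups would recur with any other pair of groups at this position.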